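The compounds below may be only part of what the source reports. "The series", "measured", "known", "first", "only" and "open" are said of these compounds alone.

Measured so far in an assay on isolated protein for inhibition of advanced glycosylation end product-specific receptor (Homo sapiens), read by FRET, with stated times of 30 min and 1 h, tested at 4 uM; a higher number here means more inhibition at the concentration tested (going by the name of the read-out), a lower number less inhibition:
- compound 1 `Clc1ccc(Oc2ccc3nc(-c4ccc(OC5CCNCC5)cc4)oc3c2)cc1`: 20.6%
- compound 2 `CN1CCC(Oc2ccc(-c3nc4ccc(Oc5ccc(Cl)cc5)cc4o3)cc2)CC1`: 19.5%
- compound 3 `CC(C)N1CCC(Oc2ccc(-c3nc4ccc(Oc5ccc(Cl)cc5)cc4o3)cc2)CC1`: 12.7%

Compound 3 sits at the lower end of the three numbers in this assay, yet neither gap separates it from the others: the step of a number 6.8 percentage points lower from compound 2 to compound 3 (within the scatter) and the step of a number 7.9 percentage points lower from compound 1 to compound 3 (within the scatter) both stay inside the usual spread of repeated measurements, as does the step of a number 1.1 percentage points lower from compound 1 to compound 2 (within the scatter). Taken together, the three compounds give numbers that cannot be told apart.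

Compound 4 `CC(C)N1CCC(COc2ccc(-c3nc4ccc(Oc5ccc(Cl)cc5)cc4o3)cc2)CC1` differs from compound 3 in one place: (1-isopropylpiperidin-4-yl)methyl in place of 1-isopropylpiperidin-4-yl on an oxygen on an aromatic ring. Among the compounds with values here, every measured step so far concerns the substituent on the amine nitrogen in a ring; none of them alters the link between the oxygen on an aromatic ring and the piperidine, so no measured step bears directly on this change. With nothing to point either way, compound 4 is expected to give a number close to that of compound 3, with the step of a number 1.3 percentage points higher from compound 3 to compound 4 (within the scatter) expected to lie within the scatter. In this assay compound 4 is therefore estimated at 14%, in a range from 3% to 26%.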

Compound 4, a percentage reported as inhibition, at one concentration (the size of the read-out at that concentration, not a potency): 26.2%
Compound 4: the middle estimate sits 12.2 percentage points below what was measured; the whole stated range lies below it.
By their numbers in this assay, from the lowest: compounds 3, 2, 1 and 4 (each within the scatter of the next, the first and the last beyond it).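

In this assay, (1-isopropylpiperidin-4-yl)methyl in place of 1-isopropylpiperidin-4-yl on an oxygen on an aromatic ring gives a number 13.5 percentage points higher from compound 3 to compound 4 (beyond the scatter); this is the first step shown that lies beyond the scatter and the first that changes anything other than the substituent on the amine nitrogen in a ring. The effect is limited, however: the other two steps, a number 6.7 percentage points higher from compound 2 to compound 4 (within the scatter) and a number 5.6 percentage points higher from compound 1 to compound 4 (within the scatter), stay within the scatter, so the numbers separate only compound 3 and compound 4 and do not set compound 4 apart from the other two compounds. Nothing available accounts for the rise seen with this change.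

The compounds shown leave open whether the added methylene carries over to piperidines with a hydrogen or a methyl on the amine nitrogen, since the (piperidin-4-yl)methyl form appears here only with isopropyl. They also leave open how a longer chain, such as an ethyl or propyl chain ending in the same 1-isopropylpiperidin-4-yl, or an open-chain dimethylamine in place of the piperidine, would read on this oxygen.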